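Selenium in Place of Sulfur on the Shared Core

The source may hold more compounds than are shown below. What is called first, only, known or untested is meant among the compounds shown, and "the series" means these compounds.

Compound 2, `CS/C(=N\C(=O)c1csc([N+](=O)[O-])c1)NC(=O)c1csc([N+](=O)[O-])c1`, was examined in a functional assay on K562 cells (Homo sapiens) for cytotoxicity, read by MTT assay, with a stated time of 72 h; on this read-out higher numbers stand for lower toxicity in this test and lower numbers for higher toxicity in this test. In this assay compound 2 reached only > 100000 nM, which is a limit of the assay and not a number. Compound 1, `CS/C(=N\C(=O)c1ccco1)NC(=O)c1ccco1`, likewise gave only the limit of > 100000 nM in this assay. Compound 3, `O=C(/N=C(/NC(=O)c1ccco1)[Se]Cc1ccccc1)c1ccco1`, gave 80600 nM in this assay. Compound 4, `C[Se]/C(=N\C(=O)c1csc([N+](=O)[O-])c1)NC(=O)c1csc([N+](=O)[O-])c1`, differs from compound 2 by a group of 2 heavy atoms (1 carbon, 1 selenium; no ring) in place of a group of 2 heavy atoms (1 carbon, 1 sulfur; no ring), on a carbon with a double bond to nitrogen.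

Going by the values given here, the only measured step that touches the same place is an at least 1.2-fold lower number from compound 1 to compound 3 (0.09 log units; that floor lies within the scatter), and that step lies within the scatter; two of the three values sit at the limit of > 100000 nM in this assay, at which 2 of the 3 values shown sit. An exchange of a sulfur for a selenium at the same place therefore gives no ground to expect a step beyond the scatter in this assay, and compound 4 is expected to remain near the limit. The step from compound 2 to compound 4 in this assay is estimated at a number no higher from compound 2 to compound 4 (the limit leaves the size open). Compound 4 is accordingly estimated at 100000 nM in this assay, with a range from 40000 nM to 300000 nM.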

Compound 4, concentration lethal to 50% of the cells: > 100000 nM
Compound 4: a limit, no number; the forecaster's own chance of this, stated with the estimate: 70%; the middle value sits exactly at the limit.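

In this assay, compound 2 and compound 4 both stand at a limit of the assay and not at a number, and the step between them cannot be read. The compounds shown leave open whether selenium in place of sulfur on this shared core changes toxicity in this test at all.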